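A benzylamine swap on the shared core

The source may hold more compounds than are shown below. What is called first, only, known or untested is meant among the compounds shown, and "the series" means these compounds.

Compound 1 `Nc1cc(N)c2nc(-c3ccccc3)c(NCc3ccc(Cl)c(Cl)c3)nc2c1` is the only one of the three measured compounds that yields a number rather than a limit. In a functional assay on NCI-H322M cells (Homo sapiens) for inhibition, read by sulforhodamine B assay, with a stated time of 48 h (on this read-out higher numbers stand for weaker inhibition of growth and lower numbers for stronger inhibition of growth), compound 1 gives 30200 nM. For compound 2 `CCOC(=O)[C@H](CCC(=O)O)NC(=O)c1ccc(Sc2nc3cc(N)cc(N)c3nc2-c2ccccc2)cc1` the result in this assay is reported only as a limit, < 100000 nM. For compound 3 `CCOC(=O)[C@H](CCC(=O)O)NC(=O)c1ccc(Oc2nc3cc(N)cc(N)c3nc2-c2ccccc2)cc1` the result in this assay is likewise a limit, < 100000 nM. Beyond compound 1, therefore, the evidence is only (the limit of < 100000 nM in this assay, at which 2 of the 3 values shown sit). Compound 4 `COc1ccc(CNc2nc3cc(N)cc(N)c3nc2-c2ccccc2)cc1` has not been measured; it differs from compound 1 by 4-methoxyphenyl in place of 3,4-dichlorophenyl on a saturated chain carbon bound to a nitrogen on an aromatic ring. Among the measured compounds shown here, no measured step joins two compounds differing in one place, so the expectation rests on compound 1 alone. The step is expected to be a 1.3-fold higher number from compound 1 to compound 4 (0.12 log units; within the scatter), within the scatter or slightly toward weaker inhibition. In this assay compound 4 is estimated at 40000 nM, with a range from 15000 nM to 100000 nM.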

Compound 4, concentration for total growth inhibition: 52500 nM
Compound 4: the middle estimate sits 1.3-fold (0.12 log units) below what was measured; measured number inside the range.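

In this assay, 4-methoxyphenyl in place of 3,4-dichlorophenyl on a saturated chain carbon bound to a nitrogen on an aromatic ring gives a 1.7-fold higher number from compound 1 to compound 4 (0.24 log units; within the scatter). Among the compounds shown here, this is the first measured step at this position, and it does not separate the two groups, even though the entering group carries a hydrogen-bond acceptor and the leaving group carries none.

As far as these compounds go, whether an amine or a carboxylic acid on this phenyl ring would move the number beyond the scatter remains open. So does the effect of a longer chain in place of the benzyl carbon.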